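This account rests on a few compounds, and the source may have more. Where it says the series, first, only, none or still open, it means among the compounds named here.

Compound 3 `COc1cc2cc(Oc3ccc(NC(=O)Nc4ccc(Cl)c(C(F)(F)F)c4)cc3)c(C)nc2cc1OC` gives -32.5% in a functional assay on SR cells (Homo sapiens) for inhibition, read by sulforhodamine B assay, with a stated time of 48 h, tested at 10 uM (on this read-out higher numbers stand for a weaker effect at the one concentration tested and lower numbers for a stronger effect), the lowest of the three numbers in hand. Compound 1 `COc1cc2cc(Oc3ccc(NC(=O)Nc4ccc(C)cc4)cc3)c(C)nc2cc1OC` gives 83.1% and compound 2 `COc1cc2cc(Oc3ccc(NC(=O)Nc4ccc(C(F)(F)F)cc4)cc3)c(C)nc2cc1OC` gives 59.6% in the same assay. Compound 4 `COc1cc2cc(Oc3ccc(NC(=O)Nc4ccc(Cl)c(Cl)c4)cc3)c(C)nc2cc1OC` differs from compound 3 by chloro in place of trifluoromethyl on an aromatic carbon, keeping the 3,4-disubstituted ring. Among the compounds with values here, the steps that bear on this change are a number 115.6 percentage points lower from compound 1 to compound 3 (beyond the scatter) and a number 92.1 percentage points lower from compound 2 to compound 3 (beyond the scatter), both large, whereas a number 23.5 percentage points lower from compound 1 to compound 2 (beyond the scatter) was only modest. Because a number 23.5 percentage points lower from compound 1 to compound 2 (beyond the scatter) shows the trifluoromethyl-for-methyl exchange alone moving the read-out only modestly, a modest rise is expected, a number 37.5 percentage points higher from compound 3 to compound 4 (beyond the scatter), with compound 4 still far below compound 1 and compound 2. Compound 4 is therefore estimated at 5%, with a range from -35% to 50%.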

Compound 4, a percentage reported as activity, at one concentration (the size of the read-out at that concentration, not a potency): 18%
Compound 4: the middle estimate sits 13 percentage points below what was measured, and the stated range covers the measured number.
By their numbers in this assay, from the lowest: compound 3; then compound 4; then compound 2; then compound 1.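

In this assay, within the data shown here, the single exchange of trifluoromethyl for chloro on this aromatic carbon gives a large step (a number 50.5 percentage points higher from compound 3 to compound 4 (beyond the scatter)), so the two groups are not interchangeable here. The 3,4-dichlorophenyl ring still stays well clear of the 4-(trifluoromethyl)phenyl and 4-methylphenyl rings (a number 41.6 percentage points lower from compound 2 to compound 4 (beyond the scatter); a number 65.1 percentage points lower from compound 1 to compound 4 (beyond the scatter)), so the 3,4-disubstituted compounds 3 and 4 both lie beyond those two. Nothing in hand accounts for the size of these steps.

Still open, as far as these compounds go, is whether a methoxy, a nitrile or an amine on this carbon would fall nearer compound 3 or compound 4. Also open is whether the order of these compounds holds in other cell lines.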